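Compound 3: octyl replaces the aryl group on the triazole

The compounds below may be only part of what the source reports. "The series", "measured", "known", "first", "only" and "open" are said of these compounds alone.

Of the compounds shown here, two have numbers so far. In a functional assay on HepG2 cells (Homo sapiens) for antiproliferative activity, read by MTT assay (on this read-out higher numbers stand for weaker inhibition and lower numbers for stronger inhibition), compound 1 (`Cc1c(-n2cc(COc3ccc(/C=C/C(=O)c4cc5c(cc4O)OC(C)(C)CC5)cc3)nn2)cccc1[N+](=O)[O-]`) gives 109000 nM and compound 2 (`Cc1c(-n2cc(COc3ccc(/C=C/C(=O)c4ccc5c(c4O)CCC(C)(C)O5)cc3)nn2)cccc1[N+](=O)[O-]`) gives 115000 nM with the two values within the usual scatter of each other. Compound 2 therefore stands level with compound 1, and the pair cannot be ranked.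

The next compound is compound 3 (`CCCCCCCCn1cc(COc2ccc(/C=C/C(=O)c3ccc4c(c3O)CCC(C)(C)O4)cc2)nn1`), which has octyl in place of 2-methyl-3-nitrophenyl on an aromatic nitrogen with the rest of compound 2 unchanged. Among the compounds with values here, no measured pair varies this group, so the data give no direct guide to the effect of the exchange, and any expectation here is tentative. A moderate step towards a lower number in this assay is expected, which would mean stronger inhibition, although a result within the scatter would be unsurprising. The estimated change is a 2.3-fold lower number from compound 2 to compound 3 (0.36 log units; beyond the scatter) with wide uncertainty on both sides. Compound 3 is estimated at 50000 nM (12000 nM to 150000 nM).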

Compound 3, half-maximal inhibitory concentration: 74100 nM
Compound 3: middle estimate off by 1.5-fold (0.17 log units), on the low side, and the stated range covers the measured number.
By their numbers in this assay, from the lowest: compounds 3, 1 and 2 (each within the scatter of the next).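

In this assay, octyl in place of 2-methyl-3-nitrophenyl on an aromatic nitrogen of the triazole amounts to a 1.6-fold lower number from compound 2 to compound 3 (0.19 log units; within the scatter), so this pair cannot be ranked. Within the data shown here, this is the first measured variation at this position, and it is a large change in what the position carries: a group with a six-membered aromatic ring of carbon only, a double bond outside the ring and two hydrogen-bond acceptors gives way to an open chain with no ring and no acceptors, yet the read-out does not separate the two compounds. No measured information bears on why this exchange leaves the two compounds level.

As far as these compounds go, whether any group here can move the number beyond the scatter remains open, for example a short chain such as methyl, an unsubstituted phenyl, or an octyl chain ending in an amine or a carboxylic acid. Also open, from the compounds shown here alone, is whether octyl gives the same outcome on the core of compound 1, where the ring oxygen and hydroxyl are arranged differently.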